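The source may hold more compounds than are shown below. What is called first, only, known or untested is meant among the compounds shown, and "the series" means these compounds.

Compound 1 `Cc1nnsc1CO/N=C/c1c(C)nn(C)c1Oc1cccc(F)c1` gives > 50000 nM in a functional assay on PANC-1 cells (Homo sapiens) for inhibition, read by MTT assay, with a stated time of 48 h (a lower number here means a stronger inhibitor, a higher number a weaker inhibitor), a limit of the assay rather than a number.
Compound 2 `Cc1nnsc1CO/N=C/c1c(C)nn(C)c1Oc1ccc(I)cc1` gives > 50000 nM in this assay, again a limit.
Compound 3 `Cc1ccc(Oc2c(/C=N/OCc3snnc3C)c(C)nn2C)cc1` gives > 50000 nM in this assay, again a limit.

All three measured compounds share one core and differ only in the aryl group on the ether oxygen. Compound 3 stands nowhere in particular on these numbers: its value is a limit, and the other two values are the same limit (the limit of > 50000 nM in this assay, at which 3 of the 3 values shown sit), so no order among compounds 1, 2 and 3 can be read. The steps a step that the two limits leave unreadable from compound 1 to compound 2, a step that the two limits leave unreadable from compound 1 to compound 3 and a step that the two limits leave unreadable from compound 2 to compound 3 are all of unreadable size for the same reason.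

Compound 4 `Cc1nnsc1CO/N=C/c1c(C)nn(C)c1Oc1ccc(C(C)(C)C)cc1` is the next member: tert-butyl in place of methyl on an aromatic carbon. The step from compound 2 to compound 3 touches the same aromatic carbon and bears most directly on it, but it gives no readable size or direction, and nothing in the other two steps helps. No step beyond the scatter is therefore expected in this assay in either direction, and the most likely outcome for compound 4 is another limit. Compound 4 is estimated at 60000 nM, with a range from 15000 nM to 200000 nM. The expected step is a step that the limit leaves unreadable from compound 3 to compound 4.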

Compound 4, half-maximal inhibitory concentration: > 50000 nM
Compound 4 gave a limit, no number; the forecaster's own chance of this, stated with the estimate: 80%; the middle value lies beyond the limit too.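

No new step can be read: compound 2, compound 3 and compound 4 all give only a limit in this assay, so the steps from compound 4 to the other two stay unreadable: the limit of > 50000 nM in this assay, at which 4 of the 4 values shown sit.

The compounds shown leave open whether any aryl group on the ether oxygen of the shared core gives a readable value in this assay, and how these groups would rank.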